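A few compounds are considered here, and "the series" means these few. Any claim that something is new, unique, unknown or untested is made for them only; others in the source may bear on it.

Compound 2 `CC/C=C/c1c(C)cc(C)c2[n+]1CC(C)C=C2` carries the shortest alkenyl chain in this set, and in a functional assay on HeLa S3 cells (Homo sapiens) for cytotoxicity, read by MTT assay, with a stated time of 48 h (on this read-out lower numbers stand for stronger inhibition and higher numbers for weaker inhibition), compound 2 gives 2000 nM. Compound 1 `CCCC/C=C/c1c(C)cc(C)c2[n+]1CC(C)C=C2` differs from compound 2 by ethyl in place of hydrogen on a saturated chain carbon, two bonds along the chain from a double-bonded chain carbon. In this assay compound 1 gives 370 nM, and the step of a 5.4-fold lower number from compound 2 to compound 1 (0.73 log units; beyond the scatter) lies beyond the scatter. Compound 3 `CCCCCCCCCCCC/C=C/c1c(C)cc(C)c2[n+]1CC(C)C=C2` carries the longest chain measured so far; in this assay compound 3 gives 38 nM, the lowest number of the three, and the step of a 9.7-fold lower number from compound 1 to compound 3 (0.99 log units; beyond the scatter) also lies beyond the scatter. How the core of compound 3 differs from that of compound 2 is not broken down here; the two values alone show compound 2 standing higher than compound 3.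

Compound 4 `CCCCCCCCCCCCCC/C=C/c1c(C)cc(C)c2[n+]1CC(C)C=C2` is related to compound 3 by ethyl in place of hydrogen on a saturated chain carbon, ten or more bonds along the chain from a double-bonded chain carbon. This is the same kind of change as that from compound 2 to compound 1, though the entering ethyl sits at a different place along the chain in the two cases. Both measured chain extensions lowered the number, but the extension from compound 1 to compound 3 added far more than an ethyl for its gain, so a smaller step than a 5.4-fold lower number from compound 2 to compound 1 (0.73 log units; beyond the scatter) is expected here, namely a 1.5-fold lower number from compound 3 to compound 4 (0.18 log units; within the scatter). Compound 4 is accordingly estimated at 25 nM, with a plausible range from 10 nM to 70 nM.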

Compound 4, half-maximal inhibitory concentration: 58 nM
The estimate for compound 4 lay 2.3-fold (0.37 log units) below the measured number; low and high end bracket the measured number.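

In this assay the step, a 1.5-fold higher number from compound 3 to compound 4 (0.18 log units; within the scatter), leaves compound 3 and compound 4 unseparated, so ethyl in place of hydrogen, which gave a clear drop in the number on the shortest chain, gives no readable change on the long one. The change therefore does not carry over as a fixed increment from one core to another in this series, and the two steps differ by more than repeated measurements would explain: the same change on two cores in this assay, a 5.4-fold lower number (0.73 log units; beyond the scatter) from compound 2 to compound 1 and a 1.5-fold higher number (0.18 log units; within the scatter) from compound 3 to compound 4, 8.3-fold (0.92 log units) apart, beyond the scatter of two such steps. This does not show what sets the two steps apart, since the entering ethyl sits at a different place along the chain in each pair and the two pairs start from chains of different length, and a single step within the scatter does not establish a ceiling for the series.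

The compounds shown leave open whether the flat result seen with compound 4 would persist with a longer chain, or whether the number would then begin to rise. They also leave open how the cytotoxic read-out would respond to a chain bearing an amine or a carboxylic acid in place of a purely hydrocarbon chain.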